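The source may report more compounds than this note shows. Statements on the series, on what has been measured and on what is new or still open speak of the compounds shown alone.

Measured so far in a functional assay on FM3A cells (Mus musculus) for cytotoxicity; a lower number here means that less compound is needed, a higher number that more compound is needed for the effect:
- compound 1 `CCCOOC1(OOCCC)CCCCCCCCCCC1` gives 12000 nM
- compound 2 `CCCCOOC1(OOCCCC)CCCCCCCCCCC1` gives 8500 nM
- compound 3 `CCCCOOC1(OOC)CCCCCCCCCCC1` gives 20000 nM

Compound 3 lies within the scatter of compound 1 and stands beyond the scatter from compound 2, on the side of the higher number. The next compound is compound 4 `COOC1(OOCCCCCC(=O)O)CCCCCCCCCCC1` with one change from compound 3: carboxymethyl in place of hydrogen on a saturated chain carbon, four bonds along the chain from an oxygen in this assay terms, that is, carboxymethyl in place of hydrogen on a saturated chain carbon, four bonds along the chain from an oxygen. Going by the values given here, the one measured step that bears on this is a 2.4-fold higher number from compound 2 to compound 3 (0.37 log units; beyond the scatter) on one of the two chains, and it bears only loosely. Among the compounds with values here, no measured compound carries a carboxymethyl group, so the data fix no firm direction. Within the data shown here, no step clearly beyond the scatter is therefore expected, with a tentative lean towards a higher number. The estimated step is a 1.5-fold higher number from compound 3 to compound 4 (0.18 log units; within the scatter) for this change. Compound 4 is expected at 30000 nM with an estimated range of 10000 nM to 90000 nM in this series.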

Compound 4, half-maximal effective concentration: 14000 nM
Compound 4: middle estimate off by 2.1-fold (0.33 log units), on the high side; the range from low to high includes it.
By their numbers in this assay, from the lowest: compounds 2, 1, 4 and 3 (each within the scatter of the next, the first and the last beyond it).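

In this assay, carboxymethyl in place of hydrogen on a saturated chain carbon, four bonds along the chain from an oxygen, gives a 1.4-fold lower number from compound 3 to compound 4 (0.15 log units; within the scatter) and so stays within the scatter. Going by these compounds alone, the earlier compounds held only plain chains, so this is the first reading of a chain end carrying a carboxylic acid, and at this position that group leaves the number in the same range as hydrogen does. Nothing available explains this result.

This single pair cannot separate the effect of the carboxylic acid from that of the added chain length, and a methyl ester, an amide or an amine at the same chain end would be needed to do so. Also open, going by these compounds, is whether a longer chain ending in the acid, or the same group on the other chain, would behave alike.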